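The source may hold more compounds than are shown below. What is called first, only, known or untested is meant among the compounds shown, and "the series" means these compounds.

Measured in a functional assay on HCT-116 cells (Homo sapiens) for cytotoxicity, read by MTT assay, with a stated time of 72 h; a lower number here means a stronger inhibitor of growth, a higher number a weaker inhibitor of growth:
compound 1 `COc1ccc(CS(=O)(=O)/C=C/c2c(OC)cccc2OC)cc1[N+](=O)[O-]` gives 10200 nM
compound 2 `COc1ccc(CS(=O)(=O)CC(=O)Nc2c(C)cc(C)cc2C)cc1[N+](=O)[O-]` gives 7910 nM
compound 3 `COc1ccc(CS(=O)(=O)CC(=O)Nc2ccccc2)cc1[N+](=O)[O-]` gives > 30000 nM, which is a limit of this assay and not a number.

Compound 3 therefore stands at the limit of > 30000 nM in this assay, at which 1 of the 3 values shown sits, and is the only one of the three without a measured number. Going by the values given here, the single measured step, an at least 3.7-fold higher number from compound 2 to compound 3 (0.57 log units; beyond the scatter), concerns the group on the amide-type nitrogen and leaves the nitro group untouched. Compound 4 `COc1ccc(CS(=O)(=O)CC(=O)Nc2ccccc2)cc1N` differs from compound 3 by amino in place of nitro on an aromatic carbon. Among the compounds with values here, no measured step involves this exchange, so there is no measured basis for the direction or size of the change in this assay. Compound 3 offers only a limit as a starting point, so any estimate for compound 4 carries a wide range. Compound 4 is expected to give 30000 nM, with a range from 8000 nM to 100000 nM. That estimate means an expected step of a number no higher from compound 3 to compound 4 (the limit leaves the size open), and a further limit rather than a number is considered likely.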

Compound 4, concentration for 50% growth inhibition: > 30000 nM
Compound 4: a limit, no number; the forecaster's own chance of this, stated with the estimate: 55%; the middle value lies on the limit itself.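

In this assay, going by these compounds alone, compound 4, like compound 3, gives a limit and not a number, so no step between the two can be read: the limit of > 30000 nM in this assay, at which 2 of the 4 values shown sit. The compounds shown leave open whether amino in place of nitro on an aromatic carbon changes growth inhibition at all, and in which direction.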